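The source may report more compounds than this note shows. Statements on the series, on what has been measured and on what is new or still open speak of the compounds shown alone.

Working notes on the series. In an assay on isolated protein for inhibition of Chymotrypsin-C (Homo sapiens), tested at 20 ug/mL (a lower number here means less inhibition, a higher number more inhibition at the concentration tested (going by the name of the read-out)), compound 3 `O=C(NC(=O)N1CCN(C(=O)CN2C(=O)C(=O)c3cc(OC(F)(F)F)ccc32)CC1)Nc1cccc2ccccc12` gives 79%, the highest of the three numbers recorded. For the measured compounds named here, compound 1 `N#Cc1cccc(NC(=O)NC(=O)N2CCN(C(=O)CN3C(=O)C(=O)c4cc(OC(F)(F)F)ccc43)CC2)c1` stands nearest with 77%, a gap inside the scatter, so the two cannot be ordered; the one measured step between them, a number 2 percentage points higher from compound 1 to compound 3 (within the scatter), confirms this. Compound 2 `CC(=O)c1ccc(NC(=O)NC(=O)N2CCN(C(=O)CN3C(=O)C(=O)c4cc(C)cc(C)c43)CC2)cc1` lies furthest off with 60%, beyond the scatter from compound 3, but compound 2 differs at two places at once and its two values with compound 3 can only be noted as they stand.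

Compound 4 `O=C(NC(=O)N1CCN(C(=O)CN2C(=O)C(=O)c3cc(Cl)ccc32)CC1)Nc1cccc2ccccc12` differs from compound 3 by chloro in place of trifluoromethoxy on an aromatic carbon. Going by the values given here, no measured pair in this set changes the substituent on that ring alone, so nothing bears directly on the step; the only clean step, between compound 1 and compound 3, concerns the other end of the molecule and was within the scatter. The change is therefore expected to give a step of a number 5 percentage points lower from compound 3 to compound 4 (within the scatter), within the scatter. Compound 4 is estimated at 74%, with a range of 55% to 90%.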

Compound 4, a percentage reported as inhibition, at one concentration (the size of the read-out at that concentration, not a potency): 82%
Compound 4: middle estimate off by 8 percentage points, on the low side; the range from low to high includes it.
By their numbers in this assay, from the lowest: compound 2; then compounds 1, 3 and 4 (each within the scatter of the next).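

For the compounds shown here, this is the first measured change at this position on an aromatic carbon. In this assay, the step of a number 3 percentage points higher from compound 3 to compound 4 (within the scatter) shows that, with the naphthalen-1-yl end held fixed, trifluoromethoxy (5 heavy atoms) and chloro (1 heavy atom) cannot be told apart at the concentration tested. Nothing at hand explains this reading.

The compounds shown carry only trifluoromethoxy or chloro at this position with the naphthalen-1-yl end, so it remains open whether an amine or a carboxylic acid there would leave the number within the scatter. Going by these compounds alone, it is also open whether chloro would read the same with the 3-cyanophenyl group in place of naphthalen-1-yl, as no pair shows both ends changing independently on that background.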